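Saturating the prop-1-en-1-yl chain in an ornithine-derived amidine

The source may hold more compounds than are shown below. What is called first, only, known or untested is meant among the compounds shown, and "the series" means these compounds.

Measured so far:
compound 1 `C=CCC(=N)NCCC[C@H](N)C(=O)O` 84%
compound 2 `C/C=C/CC(=N)NCCC[C@H](N)C(=O)O` 6%

Going by the values given here, in an assay on isolated protein for inhibition of Nitric oxide synthase, inducible (Homo sapiens), tested at 100 uM (on this read-out lower numbers stand for a stronger effect and higher numbers for a weaker effect at the one concentration tested), compound 2 gives the lowest of the two numbers; the only measured step, a number 78 percentage points lower from compound 1 to compound 2 (beyond the scatter), is large. Compound 3 `CCCC(=N)NCCC[C@H](N)C(=O)O` differs from compound 2 by ethyl in place of prop-1-en-1-yl on a saturated chain carbon bound to a carbon with a double bond to nitrogen. Among the compounds with values here, no measured step covers the loss of the double bond, so the direction of the change cannot be read from the data. Compound 3 is expected to sit between the two measured values, with an estimated step of a number 39 percentage points higher from compound 2 to compound 3 (beyond the scatter); the estimate for compound 3 is 45%, spanning 10% to 85%.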

Compound 3, a percentage reported as inhibition, at one concentration (the size of the read-out at that concentration, not a potency): 80%
Compound 3: the middle estimate sits 35 percentage points below what was measured, and the stated range covers the measured number.
By their numbers in this assay, from the lowest: compound 2; then compounds 3 and 1 (each within the scatter of the next).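

In this assay, ethyl in place of prop-1-en-1-yl gives a number 74 percentage points higher from compound 2 to compound 3 (beyond the scatter), while ethyl in place of vinyl gives a number 4 percentage points lower from compound 1 to compound 3 (within the scatter). A double bond alone therefore does not mark out the low number at this place: of the three groups, only prop-1-en-1-yl, in compound 2, goes with it. Nothing at hand explains this. Ethyl differs from prop-1-en-1-yl in both its double bond and its carbon count, and these two differences remain unseparated here. Propyl at this place would keep the carbon count without the double bond.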